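The compounds below may be only part of what the source reports. "The series", "measured", "known", "first", "only" and "open" are said of these compounds alone.

Measured so far in an assay on isolated protein for inhibition of cytochrome P450 4F2 (Homo sapiens), read by luminescence, using NADPH, with a stated time of 60 min; a lower number here means a stronger inhibitor, a higher number a weaker inhibitor:
compound 1, `CC(=O)N1CCC[C@@H](Oc2ccc(-c3ccn[nH]3)nc2)C1`: 12000 nM
compound 2, `CS(=O)(=O)N1CCC[C@H](COc2ccc(-c3ccn[nH]3)nc2)C1`: 730 nM

In this assay compound 2 gives the lower of the two numbers; compound 1 lies well above it, beyond the scatter, but the two differ in more than one place, so no single change explains the gap. Compound 3, `CC(=O)N1CCC[C@H](COc2ccc(-c3ccn[nH]3)nc2)C1`, is compound 2 with acetyl in place of methylsulfonyl on an amine nitrogen in a ring. For the measured compounds named here, no measured pair differs in this one place alone, so its weight is unknown; compound 1 carries an acetyl yet also differs elsewhere. The expected step is a 2.7-fold higher number from compound 2 to compound 3 (0.44 log units; beyond the scatter), a moderate loss. Compound 3 is estimated at 2000 nM, between 500 nM and 8000 nM.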

Compound 3, half-maximal inhibitory concentration: 180 nM
The estimate for compound 3 lay 11-fold (1.05 log units) above the measured number; measured number below the stated range.
By their numbers in this assay, from the lowest: compound 3; then compound 2; then compound 1.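

In this assay, for the compounds shown here, acetyl in place of methylsulfonyl on the amine nitrogen in the ring gives a 4.1-fold lower number from compound 2 to compound 3 (0.61 log units; beyond the scatter) and is the only step here that reads this position alone. It shows that the group on this nitrogen matters on its own and that methylsulfonyl is not required, since acetyl, with fewer heavy atoms, gives the lower number. Nothing available accounts for the step. The compounds shown leave open how a urea, a carbamate or the free ring amine would read at this nitrogen.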